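Three Measured Compounds and a Fourth Without a Number

The source may hold more compounds than are shown below. What is called first, only, known or untested is meant among the compounds shown, and "the series" means these compounds.

For the measured compounds named here, the three compounds measured so far were tested in a functional assay on DLD-1 cells (Homo sapiens) for cytotoxicity, read by MTT assay, with a stated time of 72 h; a lower number here means a stronger inhibitor, a higher number a weaker inhibitor.

Compound 1, `CCOc1cccc(/C=N/c2c(C)n(C)n(-c3ccccc3)c2=O)c1`, gives 724000000 nM.
Compound 2, `COc1ccc(/C=N/c2c(C)n(C)n(-c3ccccc3)c2=O)cc1OC`, gives 676000000 nM.
Compound 3, `COc1cc(/C=N/c2c(C)n(C)n(-c3ccccc3)c2=O)ccc1O`, gives 759000000 nM.

The three values sit close together: compound 3 is not separated from compound 1 or from compound 2 by more than the usual scatter of repeated measurements, so nothing distinguishes the three on the numbers at hand.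

Compound 4, `Cc1c(/N=C/c2ccc(O)cc2)c(=O)n(-c2ccccc2)n1C`, has not yet been measured in this assay . It differs from compound 3 in one place: hydrogen in place of methoxy on an aromatic carbon. Going by the values given here, only one measured step bears on a change of this kind, and it touches the same region of the ring: the replacement that leads from compound 2 to compound 3 gave a 1.1-fold higher number from compound 2 to compound 3 (0.05 log units; within the scatter). That step did not move the number beyond the scatter, and the three values together show no sensitivity to changes at the oxygens of this ring.

On that basis compound 4 is expected to show no step beyond the scatter, a 1.0-fold lower number from compound 3 to compound 4 (0.01 log units; within the scatter). The estimate for compound 4 is therefore 750000000 nM, with a range from 300000000 nM to 1900000000 nM.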

Compound 4, half-maximal inhibitory concentration: 646000000 nM
Compound 4: the middle estimate sits 1.2-fold (0.06 log units) above what was measured; the measured number falls inside the stated range.
By their numbers in this assay, from the lowest: compounds 4, 2, 1 and 3 (each within the scatter of the next).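

In this assay, taking the methoxy group off the aromatic carbon ortho to a hydroxy group and meta to a large group, leaving hydrogen there, gave a 1.2-fold lower number from compound 3 to compound 4 (0.07 log units; within the scatter). The earlier step had changed only the methyl on an oxygen of this ring, whereas this one removes the whole methoxy group, and the number still stays within the scatter, so among these compounds neither the methoxy group at this place nor the methyl on an oxygen shows any effect on the read-out. No supporting evidence is available that could explain this lack of change, and the result is therefore recorded only as an observation.

The compounds shown leave open whether an amine, a carboxylic acid or a chain longer than methoxy on this same aromatic carbon would move the number beyond the scatter, or whether the position stays as unresponsive as it appears here. They also leave open what would follow if the hydroxy group itself gave way to an amine or a carboxylic acid on an otherwise unchanged compound 4.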